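Removing a Piperazine Ring: Does the Core Change the Outcome?

The compounds below may be only part of what the source reports. "The series", "measured", "known", "first", "only" and "open" are said of these compounds alone.

Of the compounds shown here, three have been tested in a functional assay on PC-3 cells (Homo sapiens) for cytotoxicity, read by MTT assay, with a stated time of 72 h; a lower number here means a stronger inhibitor, a higher number a weaker inhibitor. Compound 1, with structure `N=C(Nc1ccccc1)c1cc2c(-c3ccccc3)n[nH]c2c(NC2CCCCC2)n1`, gives 1730 nM. Compound 2, with structure `CN1CCN(c2ccc(NC(=N)c3cc4c(-c5ccccc5)n[nH]c4c(NC4CCCCC4)n3)cc2)CC1`, gives 4630 nM. Compound 3, with structure `COc1ccc(Cn2ncc3cc(C(=N)Nc4ccc(N5CCN(C)CC5)cc4)ncc32)cc1`, gives 6100 nM, the highest of the three numbers, though its distance to compound 2 lies within the usual scatter.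

Compound 2 and compound 1 differ in one place: hydrogen in place of 4-methylpiperazin-1-yl on an aromatic carbon. This change produced a 2.7-fold lower number from compound 2 to compound 1 (0.43 log units; beyond the scatter), a modest but real step toward stronger inhibition.

Compound 4, with structure `COc1ccc(Cn2ncc3cc(C(=N)Nc4ccccc4)ncc32)cc1`, has not yet been measured. It relates to compound 3 exactly as compound 1 relates to compound 2: hydrogen in place of 4-methylpiperazin-1-yl on an aromatic carbon. The place is the same in both cases, on an aromatic carbon of a six-membered aromatic ring of carbon only, para to a large group, so this is the same change made a second time. The two cores, however, are not alike, and the difference between the core of compound 3 and the core of compound 2 is not broken down here.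

Because the same change once gave a 2.7-fold lower number from compound 2 to compound 1 (0.43 log units; beyond the scatter), the expected step from compound 3 to compound 4 is a 2.7-fold lower number from compound 3 to compound 4 (0.42 log units; beyond the scatter), resting on that single earlier step. Within the data shown here, compound 4 is therefore expected to give about 2300 nM in this assay, with a plausible range from 1000 nM to 5500 nM, since only one prior example of this change exists and the core differs.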

Compound 4, half-maximal inhibitory concentration: 36000 nM
For compound 4 the middle estimate is 16-fold (1.19 log units) below the measured one, and the stated range ends below it.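

In this assay, putting hydrogen in place of the 4-methylpiperazin-1-yl group on the core of compound 3 gave a 5.9-fold higher number from compound 3 to compound 4 (0.77 log units; beyond the scatter), so here the loss of that group made the compound a weaker inhibitor, whereas on the core of compound 1 it made the compound a stronger one. Set side by side, the two steps disagree in direction as well as in size, which shows that the effect of this change cannot simply be carried from one core to the other in this series: the same change on two cores in this assay, a 2.7-fold lower number (0.43 log units; beyond the scatter) from compound 2 to compound 1 and a 5.9-fold higher number (0.77 log units; beyond the scatter) from compound 3 to compound 4, 16-fold (1.20 log units) apart, beyond the scatter of two such steps What this does not show is why the direction reverses, since the two cores differ in several places at once and these two pairs cannot say which difference matters, nor whether either step is the more typical one.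

Going by these compounds, it remains open which part of the core decides the direction of the step, a question that compounds combining features of the two cores could help to settle. On these data alone, it is also open whether a smaller amine such as dimethylamino, or a morpholine ring, on the same aromatic carbon would behave like the 4-methylpiperazin-1-yl group on each core.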